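The compounds below may be only part of what the source reports. "The series", "measured", "known", "first", "only" and "open" are said of these compounds alone.

Compound 3 `Cc1nc(S(C)(=O)=O)ccc1Oc1ncnc(OC2CCN(C(=O)O[C@@H](C)CF)CC2)c1F` gives 84% in a functional assay on isolated protein for inhibition of Glucose-dependent insulinotropic receptor (Rattus norvegicus), read by HTRF and cAMP accumulation; a higher number here means a larger maximal response, a lower number a smaller maximal response. Of the three numbers measured, none lies beyond the scatter of it: compound 1 `Cc1nc(S(C)(=O)=O)ccc1Oc1ncnc(OC2CCN(C(=O)OC(C)(C)C(F)(F)F)CC2)c1F` gives 79%, and the step is a number 5 percentage points higher from compound 1 to compound 3 (within the scatter); compound 2 `Cc1nc(S(C)(=O)=O)ccc1Oc1ncnc(OC2CCN(C(=O)O[C@H](C)CF)CC2)c1F` gives 79%, and the step is a number 5 percentage points higher from compound 2 to compound 3 (within the scatter), which rests on (the fact that compounds 2 and 3 differ only in the configuration as drawn). Compound 4 `Cc1nc(S(C)(=O)=O)ccc1Oc1ncnc(OC2CCN(C(=O)O[C@H](C)C(F)(F)F)CC2)c1F` differs from compound 3 in one place: 1-(trifluoromethyl)ethyl in place of 1-(fluoromethyl)ethyl on an oxygen next to a carbonyl group. The step that bears on this change is no change at the digits printed from compound 1 to compound 2 (within the scatter), where one fluorinated ester group replaced another on the same oxygen. On that evidence, no step beyond the scatter is expected in this assay for compound 4, the expected step being a number 2 percentage points lower from compound 3 to compound 4 (within the scatter). The estimate for compound 4 is 82%, with a range from 72% to 92%.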

Compound 4, largest response reached (reported as efficacy), in percent of the reference or control that the assay uses: 85%
For compound 4 the middle estimate is 3 percentage points below the measured one, and the stated range covers the measured number.
By their numbers in this assay, from the lowest: compounds 1, 2, 3 and 4 (each within the scatter of the next).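

In this assay the 1-(trifluoromethyl)ethyl group on an oxygen next to a carbonyl group matches both drawn forms of 1-(fluoromethyl)ethyl (a number 1 percentage points higher from compound 3 to compound 4 (within the scatter); a number 6 percentage points higher from compound 2 to compound 4 (within the scatter)). The same group in place of 1-methyl-1-(trifluoromethyl)ethyl also leaves the number within the scatter (a number 6 percentage points higher from compound 1 to compound 4 (within the scatter)). Nothing shown gives a cause for these steps.

On these data alone, all the groups on this oxygen carry fluorine, so it remains open whether any group there moves the response beyond the scatter. A phenyl group, a cyclopropyl group or an unfluorinated longer chain would bear on that.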